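Cytotoxicity notes on a thiophene-benzothiazole imine series

A few compounds are considered here, and "the series" means these few. Any claim that something is new, unique, unknown or untested is made for them only; others in the source may bear on it.

Measured so far in an ADME assay on HeLa cells (Homo sapiens) for cytotoxicity, read by MTT assay, with a stated time of 72 h; on this read-out lower numbers stand for higher toxicity in this test and higher numbers for lower toxicity in this test:
compound 1 `Fc1ccc(/C=N/c2sc3c(c2-c2nc4ccccc4s2)CCC3)cc1` gives 372 ug/mL;
compound 2 `Clc1ccc(/C=N/c2sc3c(c2-c2nc4ccccc4s2)CCC3)cc1` gives 380 ug/mL;
compound 3 `C(=C/c1ccccc1)\C=N\c1sc2c(c1-c1nc3ccccc3s1)CCC2` gives 100 ug/mL.

Compound 3 has the lowest number of the three in this assay, which places it as the most toxic here; the steps of a 3.7-fold lower number from compound 1 to compound 3 (0.57 log units; beyond the scatter) and a 3.8-fold lower number from compound 2 to compound 3 (0.58 log units; beyond the scatter) both lie beyond the scatter. Compound 1 and compound 2 are within the scatter of each other, as the step of a 1.0-fold higher number from compound 1 to compound 2 (0.01 log units; within the scatter) shows.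

Compound 4 `Clc1ccc2sc(-c3c(/N=C/C=C/c4ccccc4)sc4c3CCC4)nc2c1` is not yet measured. Its change from compound 3 is chloro in place of hydrogen on an aromatic carbon. Going by the values given here, no measured step involves this position, so nothing bears directly on it. Among the compounds with values here, the only halogen change measured is a swap between two halogens on a different ring, the step of a 1.0-fold higher number from compound 1 to compound 2 (0.01 log units; within the scatter), which is within the scatter. The steps that do exceed the scatter concern the group on the imine carbon, which compound 4 keeps unchanged from compound 3.

A step of no more than the scatter is therefore expected for compound 4 in this assay, in no particular direction. The expected step is no change at the digits printed from compound 3 to compound 4 (within the scatter). Compound 4 is estimated at 100 ug/mL, with a range from 45 ug/mL to 220 ug/mL.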

Compound 4, half-maximal cytotoxic concentration: 200 ug/mL
Compound 4: middle estimate off by 2.0-fold (0.30 log units), on the low side; low and high end bracket the measured number.
By their numbers in this assay, from the lowest: compounds 3, 4, 1 and 2 (each within the scatter of the next, the first and the last beyond it).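

In this assay, chloro in place of hydrogen on an aromatic carbon of the six-membered aromatic ring, meta to a fused ring and para to a fused ring, gives a 2.0-fold higher number from compound 3 to compound 4 (0.30 log units; within the scatter) and so stays inside the usual scatter. Going by these compounds alone, this is the first reading at this position, since the earlier compounds varied only the halogen on a different ring and the group on the imine carbon, and it shows that this ring accepts a chloro with the 2-phenylethenyl group in place and no step beyond the scatter. No supporting data bear on the size of this step or on what lies behind it.

From the compounds shown here alone, a single chloro at one position says little about this ring as a whole, so it remains open whether a larger or differently charged group here, such as an amine, a carboxylic acid or a methoxy group, would also stay within the scatter. Going by these compounds, it is equally open whether the same chloro would give a step of similar size on compound 1 or compound 2, where the imine carbon carries a 4-halophenyl group instead.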